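Chloro to Methoxy: Expected Weakening of Cytotoxicity

A few compounds are considered here, and "the series" means these few. Any claim that something is new, unique, unknown or untested is made for them only; others in the source may bear on it.

Compound 1 `CC(C)(C)c1cc(C(C)(C)C)c2oc(C(c3ccc(Cl)cc3)c3c[nH]c4ccc([N+](=O)[O-])cc34)cc2c1`: 36900 nM
Compound 2 `COc1ccc(C(c2cc3cc(C(C)(C)C)cc(C(C)(C)C)c3o2)c2c[nH]c3ccc([N+](=O)[O-])cc23)cc1`: > 100000 nM
Compound 3 `Cc1c(C(c2ccccc2)c2cc3cc(Cl)ccc3o2)[nH]c2ccccc12`: 77900 nM

In a functional assay on SiHa cells (Homo sapiens) for cytotoxicity (a lower number here means a stronger inhibitor, a higher number a weaker inhibitor), compound 1 gives 36900 nM. For compound 2 the assay reports only a limit, > 100000 nM. Compound 3 gives 77900 nM. How the cores of compound 1 and compound 3 differ is not broken down here.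

The change methoxy in place of chloro on an aromatic carbon produced an at least 2.7-fold higher number from compound 1 to compound 2 (0.43 log units; beyond the scatter), with the endpoint sitting at the limit of > 100000 nM in this assay, at which 1 of the 3 values shown sits.

Compound 4 `COc1ccc2oc(C(c3ccccc3)c3[nH]c4ccccc4c3C)cc2c1` differs from compound 3 by methoxy in place of chloro on an aromatic carbon. This is the same kind of change, though the place differs: in compound 1 it is para to a large group, whereas in compound 3 it is part of a fused or bridged system of two rings, meta to a fused ring and para to a fused ring.

Compound 4 is expected to weaken by a 2.3-fold higher number from compound 3 to compound 4 (0.36 log units; beyond the scatter), resting on the step measured from compound 1 to compound 2. The estimate for compound 4 is 180000 nM, between 60000 nM and 600000 nM.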

Compound 4, half-maximal inhibitory concentration: > 100000 nM
Compound 4: a limit, no number; the forecaster's own chance of this, stated with the estimate: 65%; the middle value does not contradict the limit.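

In this assay compound 4 is reported only as a limit, > 100000 nM, and not as an exact number. Methoxy in place of chloro gives an at least 1.2-fold higher number from compound 3 to compound 4 (0.10 log units; that floor lies within the scatter), so the true size of the step on this core remains unknown. The result does not conflict with the earlier step, but it does not show that the change has the same size on both cores: the same change on two cores in this assay, an at least 2.7-fold higher number (0.43 log units; beyond the scatter) from compound 1 to compound 2 and an at least 1.2-fold higher number (0.10 log units; that floor lies within the scatter) from compound 3 to compound 4; the limit leaves it open whether they differ

The compounds shown leave open how far compound 2 and compound 4 lie past the limit. They also leave open how an amine or a carboxylic acid in place of the chloro would read in this assay.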